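This account rests on a few compounds, and the source may have more. Where it says the series, first, only, none or still open, it means among the compounds named here.

Compound 1, `COc1ccccc1CSc1nc2cc(NC(=O)C3CC3)ccc2n1C(C)C`: > 10000 nM
Compound 2, `CC(C)n1c(SCc2ccccc2Cl)nc2cc(NC(=O)C3CC3)ccc21`: > 10000 nM
Compound 3, `CCCn1c(SCc2cc([N+](=O)[O-])ccc2OC)nc2cc(NC(=O)NC(C)(C)C)ccc21`: 120 nM

Of the compounds shown here, three have been measured in an assay on isolated protein for inhibition of Gonadotropin-releasing hormone receptor (Rattus norvegicus); on this read-out higher numbers stand for weaker inhibition and lower numbers for stronger inhibition. For compound 1 the value > 10000 nM is a limit of the assay rather than a number. For compound 2 the value > 10000 nM is likewise a limit. For the measured compounds named here, compound 3 gives 120 nM, the only real number among the three. Going by the values given here, the one measured step, a step that the two limits leave unreadable from compound 1 to compound 2, cannot be sized because both of its ends sit at the limit of > 10000 nM in this assay, at which 2 of the 3 values shown sit, so its direction and size stay unknown.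

Compound 4, `CCCCCn1c(SCc2cc([N+](=O)[O-])ccc2OC)nc2cc(NC(=O)NC(C)(C)C)ccc21`, differs from compound 3 in one place: ethyl in place of hydrogen on a saturated chain carbon, three bonds along the chain from an aromatic nitrogen. Among the compounds with values here, no measured step concerns this part of the molecule, and the single step that exists is unreadable, so the measured compounds give no guide to the size of the change. The change itself is small, a longer chain on the same nitrogen with no new ring, donor or acceptor. The step of a 1.3-fold higher number from compound 3 to compound 4 (0.10 log units; within the scatter) is therefore expected to stay within the usual scatter, with no clear direction. Compound 4 is estimated at 150 nM, with a range from 40 nM to 600 nM.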

Compound 4, half-maximal inhibitory concentration: 880 nM
Estimate against measurement, compound 4: 5.9-fold (0.77 log units) below, outside the stated range (above it).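

In this assay, the chain on the aromatic nitrogen turns out not to be a place where atoms can be added freely: lengthening propyl to pentyl, with no ring, donor or acceptor entering, gives a 7.3-fold higher number from compound 3 to compound 4 (0.87 log units; beyond the scatter). For the compounds shown here, this is the first step whose size can be read, as the only earlier step cannot be read, and it shows that chain length alone at this position can shift binding beyond the usual scatter of the measurement, while compound 4 still gives a real number rather than a limit. Going by these compounds alone, nothing measured so far accounts for why the longer chain weakens inhibition.

From the compounds shown here alone, with only the propyl and pentyl chains to compare on this core, it remains open whether the number climbs steadily with length or jumps at one point, and a butyl or an ethyl chain on the same nitrogen would help to settle that. Also open, going by these compounds, is whether the extra length itself matters or only what it carries, which a chain of similar length ending in an amine or a carboxylic acid could test.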